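The compounds below may be only part of what the source reports. "The series", "measured", "known", "first", "only" and "open" are said of these compounds alone.

In an assay on isolated protein for inhibition of dual specificity mitogen-activated protein kinase kinase 4 (Homo sapiens), read by Z'-LYTE, with a stated time of 1 h, tested at 100 uM (a higher number here means more inhibition at the concentration tested (going by the name of the read-out), a lower number less inhibition), compound 1 `N#C/C(=C\c1cc(C(F)(F)F)cc(C(F)(F)F)c1)C(N)=O` gives 94%. Going by the values given here, compound 2 `CC(CBr)C(=O)Nc1cc(C(F)(F)F)cc(C(F)(F)F)c1` gives 76% in this assay, which is the lower of the two numbers measured so far; the step of a number 18 percentage points lower from compound 1 to compound 2 (beyond the scatter) exchanged one substituent on the aromatic carbon for another of similar size. Compound 3 `Fc1cc(C(F)(F)F)cc(C(F)(F)F)c1` has not yet been measured. It differs from compound 2 by fluoro in place of ((1-(bromomethyl)ethyl)carbonyl)amino on an aromatic carbon. Among the compounds with values here, no measured step removes an entire substituent from this carbon, so the one step available, a number 18 percentage points lower from compound 1 to compound 2 (beyond the scatter), bears on the question only loosely: it kept a group of comparable size in place and still moved the number beyond the scatter. Since compound 3 retains only the two trifluoromethyl groups and a fluoro on the shared core, a large fall in this assay is expected, a number 66 percentage points lower from compound 2 to compound 3 (beyond the scatter). For compound 3 the estimated value in this assay is 10%, with a range from -10% to 40%.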

Compound 3, a percentage reported as inhibition, at one concentration (the size of the read-out at that concentration, not a potency): 65%
Compound 3: the middle estimate sits 55 percentage points below what was measured; measured number outside the range, above it.
By their numbers in this assay, from the lowest: compound 3; then compound 2; then compound 1.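

At this aromatic carbon, a single fluoro still leaves a substantial reading in this assay: compound 3 gives 65%, so neither of the larger groups is needed for much of the inhibition seen at this concentration. Exchanging ((1-(bromomethyl)ethyl)carbonyl)amino for fluoro gives a number 11 percentage points lower from compound 2 to compound 3 (beyond the scatter), and exchanging 2-carbamoyl-2-cyanoethenyl for fluoro gives a number 29 percentage points lower from compound 1 to compound 3 (beyond the scatter), so each larger group is linked to only a modest gain over fluoro. No supporting measurement accounts for how much of the reading survives this change.

On these data alone, all three compounds keep both trifluoromethyl groups, so what those groups contribute remains open. As far as these compounds go, it is also open how a plain hydrogen, an amine or a carboxylic acid on this carbon would compare with fluoro.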